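Methoxy for methyl on the fused core: cytotoxicity notes

The source may report more compounds than this note shows. Statements on the series, on what has been measured and on what is new or still open speak of the compounds shown alone.

Measured so far in an ADME assay on J774.A1 cells (Mus musculus) for cytotoxicity, read by MTT assay, with a stated time of 72 h; a higher number here means that more compound is needed for the effect, a lower number that less compound is needed:
compound 1, `CC(C)Nc1nc(NCc2ccco2)c2ccccc2n1`: compound 1 gives 17000 nM
compound 2, `Cc1cccc2c(NCc3ccco3)nc(NC(C)C)nc12`: compound 2 gives > 33000 nM, a limit of the assay

Of the two values shown, compound 2 stands at the limit, (the limit of > 33000 nM in this assay, at which 1 of the 2 values shown sits), so only a floor is known for it. For the measured compounds named here, the single measured step, an at least 1.9-fold higher number from compound 1 to compound 2 (0.28 log units; that floor lies within the scatter), is a methyl in place of hydrogen on an aromatic carbon, and its floor does not rise beyond the scatter.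

Compound 3, `COc1cccc2c(NCc3ccco3)nc(NC(C)C)nc12`, is not yet measured. It differs from compound 2 in one place: methoxy in place of methyl on an aromatic carbon. Going by the values given here, no measured step exchanges methoxy for methyl; the only step that bears on this position is the one from hydrogen to methyl, which gave no change beyond the scatter. A small substituent change at the same aromatic carbon is therefore expected to move this assay little, in no fixed direction. For compound 3 the step is expected to be a step that the limit leaves unreadable from compound 2 to compound 3. Compound 3 is estimated at 40000 nM, with a range from 15000 nM to 100000 nM, and a second limit rather than a number is the likeliest outcome.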

Compound 3, half-maximal effective concentration in the J774.A1 assay: 30000 nM
Compound 3: middle estimate off by 1.3-fold (0.12 log units), on the high side; measured number inside the range.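

In the J774.A1 assay compound 3 gives 30000 nM, a number rather than a limit. A substituent at this aromatic carbon can therefore now be read against hydrogen: a 1.8-fold higher number from compound 1 to compound 3 (0.25 log units; within the scatter). Against compound 2, methoxy in place of methyl can be read only as a floor, an at least 1.1-fold lower number from compound 2 to compound 3 (0.04 log units; that floor lies within the scatter), and its true size stays hidden because compound 2 sits at a limit: the limit of > 33000 nM in the J774.A1 assay, at which 1 of the 3 values shown sits. In a physicochemical assay for permeability, using PAMPA, at pH 4 (on this read-out higher numbers stand for higher permeability and lower numbers for lower permeability), compound 2 gives 45.9 10^-6 cm/s and compound 3 gives 38.4 10^-6 cm/s. There the same exchange of methyl for methoxy gives a 1.2-fold lower number from compound 2 to compound 3 (0.08 log units; within the scatter), so this read-out also shows no change beyond the scatter.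

The compounds shown place only hydrogen, methyl and methoxy on this aromatic carbon, so it remains open whether an amine, a carboxylic acid or a longer chain such as butoxy would move the number in the J774.A1 assay beyond the scatter from compound 1. Going by these compounds, the true number of compound 2 also remains open, and with it both the size and the direction of the step from methyl to methoxy in that assay.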